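The compounds below may be only part of what the source reports. "The series", "measured", "known", "first", "only" and "open" are said of these compounds alone.

Compound 1 `N#Cc1ccc(Nc2nc(Oc3ccnc4ccccc34)nc(N3CCN(c4ncccn4)CC3)n2)cc1C(F)(F)F`: in a functional assay on DU-145 cells (Homo sapiens) for cytotoxicity, read by sulforhodamine B assay, with a stated time of 48 h (on this read-out higher numbers stand for lower toxicity in this test and lower numbers for higher toxicity in this test), compound 1 gives > 100000 nM, which is a limit of the assay. Compound 2 `N#Cc1ccc(Nc2nc(Oc3ccnc4ccccc34)nc(N3CCN(c4ccccc4)CC3)n2)cc1C(F)(F)F`: in this assay compound 2 gives > 100000 nM, again a limit.

Compound 2 therefore stands only at a limit, and (the limit of > 100000 nM in this assay, at which 2 of the 2 values shown sit). Within the data shown here, the one measured step, a step that the two limits leave unreadable from compound 1 to compound 2, is left unreadable by those two limits. Compound 3 `N#Cc1ccc(Nc2nc(Oc3ccnc4ccccc34)nc(N3CCN(c4cccc(Cl)c4Cl)CC3)n2)cc1C(F)(F)F` differs from compound 2 by 2,3-dichlorophenyl in place of phenyl on an amine nitrogen in a ring. No readable step bears on this change, so the limit of compound 2 is the only anchor. Compound 3 is accordingly expected near that limit, with an estimate of 150000 nM spanning 30000 nM to 600000 nM. The expected step is a step that the limit leaves unreadable from compound 2 to compound 3, no change beyond the scatter.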

Compound 3, concentration lethal to 50% of the cells: > 100000 nM
Compound 3: a limit, no number (the forecaster's own chance of this, stated with the estimate: 80%); the middle value does not contradict the limit.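

No step can be read among compound 1, compound 2 and compound 3, since all three values are limits: the limit of > 100000 nM in this assay, at which 3 of the 3 values shown sit.

The compounds shown leave open whether the group on the amine nitrogen in the ring affects the result in this assay at all.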